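A few compounds are considered here, and "the series" means these few. Any claim that something is new, unique, unknown or untested is made for them only; others in the source may bear on it.

The three measured compounds, all read in a functional assay on WM 266-4 cells (Homo sapiens) for inhibition, read by MTT assay, with a stated time of 24 h; on this read-out higher numbers stand for weaker inhibition of growth and lower numbers for stronger inhibition of growth:

compound 1, `COc1ccc(C2=NN(C(=O)c3ccc4c(c3)OCCO4)C(c3ccc(F)cc3)C2)cc1`: 3780 nM
compound 2, `COc1ccc(C2=NN(C(=O)c3ccc4c(c3)OCCO4)C(c3ccccc3)C2)cc1`: 2370 nM
compound 3, `COc1ccc(C2=NN(C(=O)C3COc4ccccc4O3)C(c3ccc(F)cc3)C2)cc1`: 6190 nM

Compound 1 stands second highest of the three numbers. Its nearest neighbour is compound 2, reached by a 1.6-fold lower number from compound 1 to compound 2 (0.20 log units; within the scatter), and its furthest is compound 3, reached by a 1.6-fold higher number from compound 1 to compound 3 (0.21 log units; within the scatter). Both steps lie within the scatter, so the three compounds cannot be ordered on this read-out.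

Compound 4, `O=C(c1ccc2c(c1)OCCO2)N1N=C(c2ccccc2)CC1c1ccc(F)cc1`, has not yet been measured. It differs from compound 1 at one position: hydrogen in place of methoxy on an aromatic carbon. Neither measured step touches this methoxy group; the step from compound 1 to compound 2 removes a fluoro from the other aryl ring, and the step from compound 1 to compound 3 moves the attachment point of the carbonyl substituent. Both of those changes left the number within the scatter, so the shared core has so far tolerated small edits on its periphery without a clear shift. There is no direct evidence on removing the methoxy, and the expectation is a step of a 1.2-fold higher number from compound 1 to compound 4 (0.08 log units; within the scatter) in this assay, not clearly beyond the scatter. On that basis compound 4 is estimated at 4500 nM, with a range from 1500 nM to 13000 nM.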

Compound 4, concentration for 50% growth inhibition: 5210 nM
Estimate against measurement, compound 4: 1.2-fold (0.06 log units) below, and the stated range covers the measured number.
By their numbers in this assay, from the lowest: compounds 2, 1, 4 and 3 (each within the scatter of the next, the first and the last beyond it).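

In this assay, going by these compounds alone, the change from 4-methoxyphenyl to phenyl gives a 1.4-fold higher number from compound 1 to compound 4 (0.14 log units; within the scatter) and so supplies the first direct reading at this position: the methoxy can give way to hydrogen with no step beyond the scatter. The change at this place, on a six-membered aromatic ring of carbon only and para to a large group, thus joins the two edits read earlier, at the fluoro and at the carbonyl substituent, as a third single change to the shared core whose step stays within the scatter, although none of the three can be ranked against the others. The data offer nothing that accounts for the size of this step.

The compounds shown leave open whether a hydroxyl, an amine, a carboxylic acid or a longer chain such as butoxy at this same place would give a step beyond the scatter, since hydrogen is the only replacement for methoxy among them. They also leave open how hydrogen in place of methoxy would read together with hydrogen in place of fluoro on the other aromatic ring, and whether such small steps would add up.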